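Notes on compound 1 and its unmeasured relative compound 4

A few compounds are considered here, and "the series" means these few. Any claim that something is new, unique, unknown or untested is made for them only; others in the source may bear on it.

- compound 1 `CC(C)c1ccc(OC(C)(Cc2ccc(Cl)cc2)C(=O)NS(=O)(=O)C(F)(F)F)cc1`: 5 mg/kg
- compound 2 `Cc1ccccc1S(=O)(=O)NC(=O)C(C)(Cc1ccc(Cl)cc1)Oc1ccc(C(C)C)cc1`: > 10 mg/kg (a limit)
- compound 3 `COc1ccc(S(=O)(=O)NC(=O)C(C)(Cc2ccc(Cl)cc2)Oc2ccc(C(C)C)cc2)cc1`: > 10 mg/kg (a limit)

Within the data shown here, in a functional assay on the whole organism for inhibition, with Rattus norvegicus as the target (on this read-out lower numbers stand for an effect already at smaller amounts and higher numbers for an effect only at larger amounts of compound), compound 1 gives 5 mg/kg, the only actual number. The other two values are limits. Compound 4 `CC(C)c1ccc(OC(C)(COP(=O)(O)O)Cc2ccc(Cl)cc2)cc1` differs from compound 1 as follows: a group of 6 heavy atoms (1 carbon, 4 oxygen, 1 phosphorus; no ring) in place of a group of 10 heavy atoms (2 carbon, 1 nitrogen, 3 oxygen, 3 fluorine, 1 sulfur; no ring), on a saturated chain carbon bound to an oxygen on an aromatic ring and two saturated chain carbons. Among the measured compounds shown here, two measured steps bear on this only indirectly, since each alters just the group on the sulfonyl sulfur: an at least 2.0-fold higher number from compound 1 to compound 2 (0.30 log units; that floor lies within the scatter) and an at least 2.0-fold higher number from compound 1 to compound 3 (0.30 log units; that floor lies within the scatter). On these two floors, a moderately higher number is expected in this assay, and a limit result is quite possible. The estimated step is a 3.0-fold higher number from compound 1 to compound 4 (0.48 log units; beyond the scatter). For compound 4 the estimated value is 15 mg/kg, with an expected range of 4 mg/kg to 50 mg/kg.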

Compound 4, dose for half-maximal effect: > 10 mg/kg
Compound 4: only a limit was reported (the forecaster's own chance of this, stated with the estimate: 60%); the middle value does not contradict the limit.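

In this assay, the exchange now reaches the whole ((trifluoromethyl)sulfonyl)carbamoyl group on the saturated chain carbon, not only the group on the sulfonyl sulfur, and the phosphorus-bearing replacement gives an at least 2.0-fold higher number from compound 1 to compound 4 (0.30 log units; that floor lies within the scatter). Among these compounds, compound 1 thus remains the only compound with an actual number. The true size of the step stays unreadable, as does any order among compounds 2, 3 and 4: the limit of > 10 mg/kg in this assay, at which 3 of the 4 values shown sit.

On these data alone, whether a carboxylic acid or a primary amide at this carbon would give an actual number in this assay remains open.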